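The source may report more compounds than this note shows. Statements on the series, on what has been measured and on what is new or still open speak of the compounds shown alone.

Series notes. The shared core carries a three-carbon chain ending in an aryl ether; four members are under review. Compound 1 `NC1=NC2(CCOCC2)N(OCCCOc2cccc(Cl)c2)C(N)=N1` and compound 2 `NC1=NC2(CCOCC2)N(OCCCOc2ccccc2Cl)C(N)=N1` have no number in an assay on isolated protein for inhibition of Dihydrofolate reductase (Homo sapiens), read by spectrophotometry, using NADPH, with stated times of 5 s and 6 min; on this read-out higher numbers stand for weaker inhibition and lower numbers for stronger inhibition: for compound 1 the entry is "not determined" (no result reported), and for compound 2 it is "not determined" (no result reported). For the measured compounds named here, compound 3 `COc1ccc(OCCCON2C(N)=NC(N)=NC23CCOCC3)cc1` is the only member with a measured result, so it cannot be ranked against the others; in this assay compound 3 gives 11.1 nM, and that single number is the whole reference point.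

Compound 4 `NC1=NC2(CCOCC2)N(OCCCOc2ccc(Br)cc2)C(N)=N1` is not yet measured. Compared with compound 3 the change is bromo in place of methoxy on an aromatic carbon, sitting on an aromatic carbon of a six-membered aromatic ring of carbon only, para to a large group. Going by the values given here, no pair of measured compounds bounds this change, so the expected step from compound 3 to compound 4 in this assay is a 1.2-fold lower number from compound 3 to compound 4 (0.09 log units; within the scatter), which is within the usual scatter, with no direction claimed beyond it. Compound 4 is therefore estimated at 9 nM in this assay, with a range of 3 nM to 27 nM.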

Compound 4, half-maximal inhibitory concentration: 32.5 nM
The estimate for compound 4 lay 3.6-fold (0.56 log units) below the measured number; measured number above the stated range.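

The series now has its first readable step: at the aromatic carbon para to a large group, 4-methoxyphenyl to 4-bromophenyl gives a 2.9-fold higher number from compound 3 to compound 4 (0.47 log units; beyond the scatter) in this assay. This position is therefore not indifferent to the group it carries, and of this pair compound 3 shows the stronger inhibition, although the step is only modest. No supporting measurement is available to account for the step.

A single pair leaves open whether this step is specific to bromo or would extend to other groups on the same carbon, such as an amine or a carboxylic acid. Steps involving compound 1 and compound 2 cannot be read, so how a chloro group on the ring compares with either group here also remains open.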